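The compounds below may be only part of what the source reports. "The series", "measured", "known", "first", "only" and "open" are said of these compounds alone.

Among the compounds with values here, in an ADME assay on HEL cells (Homo sapiens) for cytotoxicity (a higher number here means that more compound is tolerated, a lower number that less compound is tolerated), compound 1 `Cc1ccc(-[n+]2noc([O-])c2CN2CCN(c3cccc(Cl)c3Cl)CC2)cc1` gives 28.8 ug/mL, the only exact number so far. Compound 2 `[O-]c1on[n+](-c2ccc(Cc3ccc(-[n+]4noc([O-])c4CN4CCN(c5cccc(Cl)c5)CC4)cc3)cc2)c1CN1CCN(c2cccc(Cl)c2)CC1` reads > 100 ug/mL, which is a limit of this assay and not a number. Compound 3 `Cc1ccc(-[n+]2noc([O-])c2CN2CCN(c3ccccc3)CC2)cc1` differs from compound 1 in one place: phenyl in place of 2,3-dichlorophenyl on an amine nitrogen in a ring, with phenyl in place of 2,3-dichlorophenyl on an amine nitrogen in a ring. Within the data shown here, no measured step shows what this change does, so only a modest shift toward more compound tolerated is expected, an estimated step of a 1.6-fold higher number from compound 1 to compound 3 (0.19 log units; within the scatter). Compound 3 is estimated at 45 ug/mL, with an expected range of 18 ug/mL to 100 ug/mL.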

Compound 3, half-maximal cytotoxic concentration: 20 ug/mL
Compound 3: middle estimate off by 2.3-fold (0.35 log units), on the high side; the measured number falls inside the stated range.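

In this assay, within the data shown here, phenyl in place of 2,3-dichlorophenyl on an amine nitrogen in a ring gives a 1.4-fold lower number from compound 1 to compound 3 (0.16 log units; within the scatter), the first measured step at this position. The two compounds therefore cannot be told apart, and the two chlorine atoms make no difference beyond the scatter in this pair. Nothing at hand gives a cause for this step.

Still open, from the compounds shown here alone, is whether a carboxylic acid or a methoxy group on this phenyl would move the number beyond the scatter. A single step also says nothing about changes elsewhere on the core.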